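Dropping the tert-butyl group from a weak oxadiazole analogue

The source may report more compounds than this note shows. Statements on the series, on what has been measured and on what is new or still open speak of the compounds shown alone.

Measured so far:
- compound 1 `CC(C)c1nnc(-c2ccc(N3CCC(Oc4ccccc4C(F)(F)F)CC3)nn2)s1`: 8.8 nM in an assay on microsomes from liver for inhibition of acyl-CoA desaturase 1 (Rattus norvegicus); on this read-out lower numbers stand for stronger inhibition and higher numbers for weaker inhibition
- compound 2 `CC(C)(C)c1nnc(-c2ccc(N3CCC(Oc4ccccc4C(F)(F)F)CC3)nn2)o1`: 980 nM in this assay

Compound 2 stands as the higher of the two numbers, and the gap to compound 1 is large: a 110-fold higher number from compound 1 to compound 2 (2.05 log units; beyond the scatter). That step, however, changes both the ring and the alkyl group at once, so it does not isolate the alkyl group on its own.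

Compound 3 `FC(F)(F)c1ccccc1OC1CCN(c2ccc(-c3nnco3)nn2)CC1` differs from compound 2 by hydrogen in place of tert-butyl on an aromatic carbon. For the measured compounds named here, no measured step shows what removing this alkyl group alone does in this assay, so the direction of the step cannot be read from the data, and the expectation must stay wide. The estimated step is a 2.6-fold higher number from compound 2 to compound 3 (0.41 log units; beyond the scatter), a small shift toward a higher number with much room either way. Compound 3 is expected to give 2500 nM in this assay, within a range of 500 nM to 15000 nM.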

Compound 3, half-maximal inhibitory concentration: 22 nM
The estimate for compound 3 lay 110-fold (2.06 log units) above the measured number; the whole stated range lies above it.
By their numbers in this assay, from the lowest: compound 1; then compound 3; then compound 2.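

Taking the tert-butyl group off this carbon of the oxadiazole ring gives a 45-fold lower number from compound 2 to compound 3 (1.65 log units; beyond the scatter) in this assay, so most of the weakness of compound 2 goes with the tert-butyl group and not with the oxadiazole ring as such. The unsubstituted 1,3,4-oxadiazol-2-yl group also comes fairly close to the 5-isopropyl-1,3,4-thiadiazol-2-yl group, with a 2.5-fold higher number from compound 1 to compound 3 (0.40 log units; beyond the scatter) as a modest step that still lies beyond the scatter. Nothing available explains why the tert-butyl group costs so much.

The compounds shown leave open how a smaller group on this carbon, such as methyl, or a group of another kind, such as an amine, would behave in the oxadiazole series. They also cannot separate the effect of the ring from that of its alkyl group, since no oxadiazole here carries an isopropyl group and no thiadiazole here carries a tert-butyl group.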